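A few compounds are considered here, and "the series" means these few. Any claim that something is new, unique, unknown or untested is made for them only; others in the source may bear on it.

For the measured compounds named here, compound 2 `O=C(NCCCCCCCn1cc(-c2cccnc2)nn1)c1ccccc1-n1ccnn1` gives the lower of the two numbers measured so far in an assay for inhibition of Nicotinamide phosphoribosyltransferase (Mus musculus), read by fluorescence, with a stated time of 1 h, in the presence of a further agent that is not named here (a lower number here means a stronger inhibitor, a higher number a weaker inhibitor), at 3.4 nM. Going by the values given here, compound 1 `O=C(NCCCCCCCn1cc(-c2cccnc2)nn1)c1ccccc1-c1cccnc1`, the only other measured compound, gives 28.5 nM in this assay; the step of an 8.4-fold lower number from compound 1 to compound 2 (0.92 log units; beyond the scatter) exchanged one ring for another on the shared core. Compound 3 `O=C(NCCCCCCCn1cc(-c2cccnc2)nn1)c1ccccc1-n1cc(CN2CCCC2)nn1` differs from compound 2 in another way: (pyrrolidin-1-yl)methyl in place of hydrogen on an aromatic carbon. None of the measured steps concerns a group added in this way, so the single step shown, an 8.4-fold lower number from compound 1 to compound 2 (0.92 log units; beyond the scatter), gives no direction for what comes next. With no ground for a gain or a loss, the expected outcome is a number near that of compound 2. For compound 3 the step of a 1.2-fold higher number from compound 2 to compound 3 (0.07 log units; within the scatter) is expected to stay within the scatter. The estimate for compound 3 in this assay is 4 nM, with a range from 1 nM to 16 nM.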

Compound 3, half-maximal inhibitory concentration: 25.4 nM
Compound 3: the middle estimate sits 6.4-fold (0.80 log units) below what was measured; measured number above the stated range.
By their numbers in this assay, from the lowest: compound 2; then compounds 3 and 1 (each within the scatter of the next).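

The aromatic carbon of the 1H-1,2,3-triazol-1-yl group is not a neutral place to add to in this assay: (pyrrolidin-1-yl)methyl there gives a 7.5-fold higher number from compound 2 to compound 3 (0.87 log units; beyond the scatter) and so loses most of what compound 2 had gained. Set against the pyridin-3-yl group of compound 1, the substituted ring gives a 1.1-fold lower number from compound 1 to compound 3 (0.05 log units; within the scatter) and lies within the scatter, so with this addition the advantage of the 1H-1,2,3-triazol-1-yl group over pyridin-3-yl is no longer seen. Nothing measured here gives a reason for this loss.

Still open, from the compounds shown here alone, is whether a plain methyl or a hydroxymethyl on this carbon would keep the low number of compound 2. An open-chain amine such as dimethylaminomethyl, or a carboxylic acid, could show whether the pyrrolidine ring itself matters.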